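A few compounds are considered here, and "the series" means these few. Any claim that something is new, unique, unknown or untested is made for them only; others in the source may bear on it.

Of the compounds shown here, two have been measured in a functional assay on DU-145 cells (Homo sapiens) for inhibition, read by MTT assay, with a stated time of 48 h (on this read-out higher numbers stand for weaker inhibition and lower numbers for stronger inhibition), so far.

- compound 1 `Cc1ccc(OCc2cn(-c3ccc(NS(C)(=O)=O)c(Oc4ccccc4)c3)nn2)cc1` gives 8200 nM
- compound 2 `Cc1cc(OCc2cn(-c3ccc(NS(C)(=O)=O)c(Oc4ccccc4)c3)nn2)ccc1Cl` gives 5900 nM

Compound 2 has only compound 1 to be compared with, and the two cannot be told apart on these numbers. The next compound is compound 3 `CS(=O)(=O)Nc1ccc(-n2cc(COc3ccc([N+](=O)[O-])cc3)nn2)cc1Oc1ccccc1`, which has not yet been measured. It keeps the shared core and carries 4-nitrophenyl in place of 4-chloro-3-methylphenyl on an oxygen on a saturated carbon.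

Going by the values given here, only one measured step bears on this place in the molecule: a 1.4-fold lower number from compound 1 to compound 2 (0.14 log units; within the scatter). That step is small, so exchanging one substituted phenyl group for another has so far made no clear difference. Among the compounds with values here, it is thin evidence, however, and no measured compound carries a 4-nitrophenyl group. Unlike the group it replaces, this one has hydrogen-bond acceptors, so the range must stay wide.

In this assay no shift beyond the scatter is expected, and the estimated change is a 1.1-fold higher number from compound 2 to compound 3 (0.04 log units; within the scatter) in size. For compound 3 the expected value is 6500 nM (estimated range 2500 nM to 16000 nM).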

Compound 3, half-maximal inhibitory concentration: 7200 nM
The estimate for compound 3 lay 1.1-fold (0.04 log units) below the measured number; the measured number falls inside the stated range.
By their numbers in this assay, from the lowest: compounds 2, 3 and 1 (each within the scatter of the next).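

In this assay, 4-nitrophenyl in place of 4-chloro-3-methylphenyl gives a 1.2-fold higher number from compound 2 to compound 3 (0.09 log units; within the scatter), and nitro in place of methyl on an aromatic carbon gives a 1.1-fold lower number from compound 1 to compound 3 (0.06 log units; within the scatter), so neither step can be told from repeat-measurement noise. The earlier pair compared only groups without hydrogen-bond acceptors, whereas 4-nitrophenyl has them, and in this assay even that difference in the group on the oxygen leaves compound 3 indistinguishable from compound 1 and compound 2. All three substituted phenyl groups therefore sit at the same level on these numbers, which widens the range of groups that this position has tolerated without a clear shift. No measurement is at hand that could account for this flat result.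

On these data alone, all three compounds carry a single substituted phenyl ring on this oxygen, so it remains open whether a phenyl ring bearing an amine or a carboxylic acid, or a cyclohexyl group or a longer saturated chain in place of the ring, would move the number beyond the scatter. Whether any change at this position can shift the result clearly in either direction also remains unanswered.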